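Benzyl for Methylsulfonyl on the Amine of Compound 2

The compounds below may be only part of what the source reports. "The series", "measured", "known", "first", "only" and "open" are said of these compounds alone.

Compound 1, `Cc1cccc(C(=O)Nc2ccc3c(c2)CC(NS(=O)(=O)c2ccccc2)C3)c1-c1ccc(C#N)cc1`: 5.5 nM
Compound 2, `CS(=O)(=O)NC1Cc2ccc(NC(=O)c3ccccc3-c3ccc(C(F)(F)F)cc3)cc2C1`: 60 nM
Compound 3, `Cc1cccc(C(=O)Nc2ccc3c(c2)CC(NS(=O)(=O)c2cccs2)C3)c1-c1ccc(Cl)cc1`: 3 nM

Of the compounds shown here, three on a shared core have been measured in an assay for inhibition of apolipoprotein B-100 (Homo sapiens), tested at 100 nM; on this read-out higher numbers stand for weaker inhibition and lower numbers for stronger inhibition. Compound 2 gives the highest of the three numbers; compound 1 and compound 3 both stand lower, each beyond the scatter. Compound 4, `O=C(Nc1ccc2c(c1)CC(NCc1ccccc1)C2)c1ccccc1-c1ccc(C(F)(F)F)cc1`, differs from compound 2 by benzyl in place of methylsulfonyl on an amine nitrogen, read one bond further out as methanesulfonamido to benzylamino. For the measured compounds named here, no measured pair shows this change, so its size is not known from the data. The step from compound 2 to compound 4 is expected to be a moderate rise, a 2.5-fold higher number from compound 2 to compound 4 (0.40 log units; beyond the scatter), with wide uncertainty. Compound 4 is estimated at 150 nM, with a range from 30 nM to 800 nM.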

Compound 4, half-maximal inhibitory concentration: 340 nM
Beside the measured number, compound 4's estimate is 2.3-fold (0.36 log units) below it, within the range that was stated.
By their numbers in this assay, from the lowest: compounds 3 and 1 (each within the scatter of the next); then compound 2; then compound 4.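

Putting benzyl in place of methylsulfonyl on the amine nitrogen gives, in this assay, a 5.7-fold higher number from compound 2 to compound 4 (0.75 log units; beyond the scatter), the only step measured at this position among the compounds shown. This single pair therefore shows that the substituent on this nitrogen affects the read-out, and that benzyl goes with weaker inhibition here than methylsulfonyl. No measured finding explains the step. The compounds shown leave open how an acetyl group, a benzoyl group or an unsubstituted amine would read at this nitrogen. They also leave open whether the step would keep its size with the other amide portion found in compound 1.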